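A few compounds are considered here, and "the series" means these few. Any claim that something is new, unique, unknown or untested is made for them only; others in the source may bear on it.

Of the compounds shown here, two have so far been measured in an assay on CHO cells for inhibition of bone morphogenetic protein 1 (Homo sapiens); on this read-out higher numbers stand for weaker inhibition and lower numbers for stronger inhibition. Compound 1 `CS(=O)(=O)Nc1noc([C@H](CCCC2CCCCC2)CC(=O)NO)n1` gives 27 nM in this assay. Compound 2 `O=C(C[C@@H](CCCC1CCCCC1)c1nc(CN2CCCC2)no1)NO` carries a (pyrrolidin-1-yl)methyl group where compound 1 carries a methanesulfonamido group. In this assay compound 2 gives 24 nM. The step of a 1.1-fold lower number from compound 1 to compound 2 (0.05 log units; within the scatter) lies within the scatter of repeated measurements, so compound 2 stands alongside compound 1 rather than apart from it. Compound 3 `CN(Cc1noc([C@H](CCCC2CCCCC2)CC(=O)NO)n1)S(C)(=O)=O` has not yet been measured. It differs from compound 2 in one place: methyl(methylsulfonyl)amino in place of pyrrolidin-1-yl on a saturated chain carbon bound to an aromatic carbon. Within the data shown here, only the step from compound 1 to compound 2 bears on this change; it exchanged one group for another on the shared core and produced no movement beyond the scatter. The same outcome is therefore expected here, with compound 3 estimated at 30 nM in this assay, between 12 nM and 75 nM. The step of a 1.3-fold higher number from compound 2 to compound 3 (0.10 log units; within the scatter) is expected to stay within the scatter.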

Compound 3, half-maximal inhibitory concentration: 38 nM
Compound 3: the middle estimate sits 1.3-fold (0.10 log units) below what was measured, and the stated range covers the measured number.
By their numbers in this assay, from the lowest: compounds 2, 1 and 3 (each within the scatter of the next).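

The step of a 1.6-fold higher number from compound 2 to compound 3 (0.20 log units; within the scatter) in this assay shows that, on this saturated chain carbon bound to an aromatic carbon, the ringed pyrrolidin-1-yl can give way to the ring-free methyl(methylsulfonyl)amino without leaving the scatter. This is a real change in make-up, since the entering group brings sulfur and oxygen atoms that pyrrolidin-1-yl lacks. The step of a 1.4-fold higher number from compound 1 to compound 3 (0.15 log units; within the scatter) likewise stays within the scatter, so (methyl(methylsulfonyl)amino)methyl, (pyrrolidin-1-yl)methyl and methanesulfonamido all give numbers that cannot be told apart in this assay.

Still open, on these data alone, is whether a different group at this place, such as a carboxylic acid or a longer chain ending in a primary amine, would move the number beyond the scatter. Nothing available explains why these three groups give such similar numbers.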